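Indole for indane on the thiourea nitrogen: cytotoxicity outlook

This account rests on a few compounds, and the source may have more. Where it says the series, first, only, none or still open, it means among the compounds named here.

Measured compounds:
- compound 1 `NC(=S)Nc1cccc(OCCCCCCCCNC(=S)Nc2ccccc2)c1`: > 50000 nM
- compound 2 `NC(=S)Nc1cccc(OCCCCCCCCNC(=S)Nc2ccc(Cl)cc2)c1`: 18000 nM
- compound 3 `NC(=S)Nc1cccc(OCCCCCCCCNC(=S)Nc2ccc3c(c2)CCC3)c1`: 34000 nM

In an ADME assay on Huh-7 cells (Homo sapiens) for cytotoxicity (a lower number here means that less compound is tolerated, a higher number that more compound is tolerated), compound 1 gives > 50000 nM, which is a limit of the assay and not a number (the limit of > 50000 nM in this assay, at which 1 of the 3 values shown sits). Compound 2 gives 18000 nM and compound 3 gives 34000 nM in this assay. Compound 3 therefore holds the highest of the two numbers shown, with compound 2 nearest: a 1.9-fold higher number from compound 2 to compound 3 (0.28 log units; within the scatter). Against the limit of compound 1 the steps are an at least 2.7-fold lower number from compound 1 to compound 2 (0.44 log units; beyond the scatter) and an at least 1.4-fold lower number from compound 1 to compound 3 (0.16 log units; that floor lies within the scatter).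

Compound 4 `NC(=S)Nc1cccc(OCCCCCCCCNC(=S)Nc2ccc3[nH]ccc3c2)c1` differs from compound 3 in one place: 1H-indol-5-yl in place of 2,3-dihydro-1H-inden-5-yl on an amide-type nitrogen. For the measured compounds named here, no measured step changes a ring of this kind; the two steps from compound 1 show that substituents on the phenyl of this thiourea move the number only modestly, and the step from compound 2 to compound 3 stays within the scatter. The expected step of a 1.2-fold higher number from compound 3 to compound 4 (0.07 log units; within the scatter) is therefore none beyond the scatter. Compound 4 is estimated at 40000 nM in this assay, within 15000 nM to 80000 nM.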

Compound 4, half-maximal cytotoxic concentration: 18000 nM
Beside the measured number, compound 4's estimate is 2.2-fold (0.35 log units) above it; low and high end bracket the measured number.
By their numbers in this assay, from the lowest: compounds 2, 4 and 3 (each within the scatter of the next). At a limit, above all of these: compound 1.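

For the compounds shown here, on the amide-type nitrogen, 1H-indol-5-yl is the first group with a ring hetero atom at this place, and in this assay it stays within the scatter of both carbon-only groups: a 1.9-fold lower number from compound 3 to compound 4 (0.28 log units; within the scatter), and no change at the digits printed from compound 2 to compound 4 (within the scatter). Compound 1 stands at a limit of the assay and not at a number: the limit of > 50000 nM in this assay, at which 1 of the 4 values shown sits. Only a floor can therefore be read against phenyl, an at least 2.7-fold lower number from compound 1 to compound 4 (0.44 log units; beyond the scatter), and this floor lies beyond the scatter, as the floor for 4-chlorophenyl does, whereas the floor for 2,3-dihydro-1H-inden-5-yl does not.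

Where a 1-methyl-1H-indol-5-yl or a pyridine ring at this place would fall in this assay remains open. So does the outcome for a shorter chain in place of the present one.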